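Replacing 4-methoxyphenyl with pyridin-3-yl: metabolic stability

A few compounds are considered here, and "the series" means these few. Any claim that something is new, unique, unknown or untested is made for them only; others in the source may bear on it.

Measured so far in an ADME assay on microsomes from liver (Rattus norvegicus) for metabolic stability, read by LC-MS, tested at 0.5 uM; on this read-out higher numbers stand for a longer-lived compound and lower numbers for a shorter-lived compound:
- compound 1 `COc1ccc(CCOc2ccc(-c3c(C)nc(C)c([C@H](OC(C)(C)C)C(=O)O)c3N3CCC(C)(C)CC3)cc2)cc1` gives > 2 h
- compound 2 `Cc1nc(C)c([C@H](OC(C)(C)C)C(=O)O)c(N2CCC(C)(C)CC2)c1-c1ccc(OCCc2ccccn2)cc1` gives 1.02 h

The value for compound 1 is a limit of the assay and not a number, so among the numbers shown compound 1 stands only at that limit (the limit of > 2 h in this assay, at which 1 of the 2 values shown sits). Compound 3 `Cc1nc(C)c([C@H](OC(C)(C)C)C(=O)O)c(N2CCC(C)(C)CC2)c1-c1ccc(OCCc2cccnc2)cc1` differs from compound 1 by pyridin-3-yl in place of 4-methoxyphenyl on a saturated chain carbon, two bonds along the chain from an oxygen on an aromatic ring. Among the measured compounds shown here, the one measured step that bears on this change is an at least 1.9-fold lower number from compound 1 to compound 2 (0.29 log units; that floor lies within the scatter), where a related ring took the place of the same 4-methoxyphenyl group. For the measured compounds named here, that step is the only guide, and its floor lies within the scatter, so in this assay a drop from compound 1 to compound 3 of about that size, or none beyond the scatter, is expected. Compound 3 is expected to give 1.1 h, within 0.5 h to 2.5 h. The expected step is an at least 1.8-fold lower number from compound 1 to compound 3 (0.25 log units; that floor lies within the scatter).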

Compound 3, half-life: 0.783 h
Compound 3: the middle estimate sits 1.4-fold (0.15 log units) above what was measured; measured number inside the range.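

In this assay, the step to a pyridine ring now clears the scatter, which the earlier step did not show: an at least 2.5-fold lower number from compound 1 to compound 3 (0.40 log units; beyond the scatter). From the compounds shown here alone, compound 1 holds a limit of the assay and not a number, so this step is only a floor, and its true size is unknown: the limit of > 2 h in this assay, at which 1 of the 3 values shown sits. Pyridin-3-yl and pyridin-2-yl cannot be told apart at this place, with a 1.3-fold lower number from compound 2 to compound 3 (0.11 log units; within the scatter).

The compounds shown leave open whether the shorter half-life goes with losing the methoxy group or with bringing in the ring nitrogen. A plain phenyl at this place would separate those two changes, and pyridin-4-yl would show whether the third pyridine ring reads like the other two.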